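From morpholin-4-yl to dimethylamino on a carbonyl carbon

The compounds below may be only part of what the source reports. "The series", "measured", "known", "first", "only" and "open" are said of these compounds alone.

In an ADME assay on the whole organism (plasma) for pharmacokinetics, with Rattus norvegicus as the target, at a dose of 5 mg/kg by the oral route (on this read-out higher numbers stand for higher exposure at the dose given and lower numbers for lower exposure), compound 1 (`CCC(CC)[C@@H]1C(=O)N[C@H](C2Cc3ccccc3C2)C(=O)N1[C@@H](C(=O)N1CCOCC1)c1ccc(C)nc1`) gives 1380 ng.h/mL and compound 2 (`CCC(CC)[C@@H]1C(=O)N[C@H](C2Cc3ccccc3C2)C(=O)N1[C@@H](C(=O)N1CCOCC1)c1ccc(C)nc1C`) gives 2330 ng.h/mL on the same scale, and these two values lie within the scatter of each other. Compound 3 (`CCC(CC)[C@@H]1C(=O)N[C@H](C2Cc3ccccc3C2)C(=O)N1[C@@H](C(=O)N(C)C)c1ccc(C)nc1`) has dimethylamino in place of morpholin-4-yl on a carbonyl carbon. For the measured compounds named here, the only measured step shows a 1.7-fold higher number from compound 1 to compound 2 (0.23 log units; within the scatter) for methyl in place of hydrogen on an aromatic carbon, a different change, so no measured step speaks directly to this one. No step beyond the scatter is therefore expected in this assay for this change. Compound 3 is expected at 1350 ng.h/mL within an estimated range of 520 ng.h/mL to 3500 ng.h/mL for a repeat measurement. This estimate means a 1.0-fold lower number from compound 1 to compound 3 (0.01 log units; within the scatter) as the expected step.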

Compound 3, area under the concentration-time curve: 1810 ng.h/mL
Beside the measured number, compound 3's estimate is 1.3-fold (0.13 log units) below it, and the stated range covers the measured number.
By their numbers in this assay, from the lowest: compounds 1, 3 and 2 (each within the scatter of the next).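

With dimethylamino in place of morpholin-4-yl on the carbonyl carbon, this assay shows a 1.3-fold higher number from compound 1 to compound 3 (0.12 log units; within the scatter), so at this place the six-membered ring can give way to an open amine without the exposure leaving the scatter. The earlier pair spoke only to a methyl on an aromatic carbon, not to this carbonyl substituent. Nothing at hand accounts for this result. From the compounds shown here alone, whether a piperidin-1-yl or pyrrolidin-1-yl group, or a carboxylic acid in place of the amide, would stay within the scatter remains open. So does how dimethylamino behaves together with the added methyl of compound 2.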